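Second methoxy on the enone aryl ring: two cores

The compounds below may be only part of what the source reports. "The series", "measured", "known", "first", "only" and "open" are said of these compounds alone.

Compound 1 `C=C(Br)C(=O)Nc1ccc(C(=O)/C=C/c2ccc(OC)cc2)cc1` and compound 2 `C=C(Br)C(=O)Nc1ccc(C(=O)/C=C/c2ccc(OC)c(OC)c2)cc1` share one core, while compound 3 `COc1ccccc1/C=C/C(=O)c1ccc(N)cc1` and compound 4 `COc1cccc(/C=C/C(=O)c2ccc(N)cc2)c1OC` share another; the difference between the two cores is not broken down here. In a functional assay on HeLa cells (Homo sapiens) for antiproliferative activity, with a stated time of 48 h (a lower number here means a stronger inhibitor, a higher number a weaker inhibitor), compound 1 gives 310 nM and compound 2 gives 770 nM. The change between them is methoxy in place of hydrogen on an aromatic carbon, and it produced a 2.5-fold higher number from compound 1 to compound 2 (0.40 log units; beyond the scatter). Compound 3 gives 7800 nM in this assay, the highest number of the three measured, standing beyond the scatter from both compound 2 and compound 1.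

Compound 4 carries the same change relative to compound 3: methoxy in place of hydrogen on an aromatic carbon. For the measured compounds named here, only one measured instance of this change exists, and it sits on a different core, so the transfer is uncertain. The step expected in this assay is a 2.1-fold higher number from compound 3 to compound 4 (0.31 log units; beyond the scatter), set beside a 2.5-fold higher number from compound 1 to compound 2 (0.40 log units; beyond the scatter) as its only basis, with a wider margin because the starting number of compound 3 is already 7800 nM. Compound 4 is therefore estimated at 16000 nM, with a likely range from 5000 nM to 50000 nM.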

Compound 4, half-maximal inhibitory concentration: 6800 nM
For compound 4 the middle estimate is 2.4-fold (0.37 log units) above the measured one; low and high end bracket the measured number.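

On the core of compound 3, the added methoxy leaves the read-out in this assay essentially unmoved, with a 1.1-fold lower number from compound 3 to compound 4 (0.06 log units; within the scatter), so the higher number seen on the other core does not recur here. The result of this change therefore depends on the core it is placed on, and the step on one core did not predict the step on the other: the same change on two cores in this assay, a 2.5-fold higher number (0.40 log units; beyond the scatter) from compound 1 to compound 2 and a 1.1-fold lower number (0.06 log units; within the scatter) from compound 3 to compound 4, 2.8-fold (0.45 log units) apart, beyond the scatter of two such steps

This rests on a single pair per core, and the difference between the cores is not broken down, so it does not show which part of the core separates the two steps or whether the gap would hold for further pairs.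

The compounds shown leave open whether a hydroxy group or a fluorine atom in place of the added methoxy would also give different steps on the two cores. Also open, going by these compounds, is whether a longer alkoxy chain, such as ethoxy, would follow the methoxy result on either core.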